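Hydroxy in place of dimethylamino on a longer thioether chain

The compounds below may be only part of what the source reports. "The series", "measured", "known", "first", "only" and "open" are said of these compounds alone.

Measured compounds:
compound 1 `Cn1c(Cc2nn(CCCO)c(=O)c3ccccc23)nnc1SCC(=O)Nc1ccc(Cl)cc1Cl`: > 30000 nM
compound 2 `CN(C)CCCn1nc(Cc2nnc(SCC(=O)Nc3ccc(Cl)cc3Cl)n2C)c2ccccc2c1=O`: 18800 nM
compound 3 `CN(C)CCCn1nc(Cc2nnc(SCCCCCCCC(=O)Nc3ccc(Cl)cc3Cl)n2C)c2ccccc2c1=O`: 2300 nM

Of the compounds shown here, three have been tested in an assay on 32D cells for inhibition of interleukin-15 (Mus musculus), read by resazurin assay, with stated times of 30 min and 2.5 days, in the presence of a further agent that is not named here; on this read-out higher numbers stand for weaker inhibition and lower numbers for stronger inhibition. Compound 2 gives 18800 nM. Compound 3 gives 2300 nM, the lower of the two numbers; its difference from compound 2 is not broken down here, and the gap between the two values is beyond the scatter. Compound 1 reaches only a limit of this assay, > 30000 nM, not a number; this is the limit of > 30000 nM in this assay, at which 1 of the 3 values shown sits.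

Compound 1 differs from compound 2 by hydroxy in place of dimethylamino on a saturated chain carbon, three bonds along the chain from an aromatic nitrogen. The step is an at least 1.5-fold higher number from compound 2 to compound 1 (0.20 log units; that floor lies within the scatter); as the value of compound 1 is a limit, only a floor for the step is known.

Compound 4 `Cn1c(Cc2nn(CCCO)c(=O)c3ccccc23)nnc1SCCCCCCCC(=O)Nc1ccc(Cl)cc1Cl` has not yet been measured in this assay. It differs from compound 3 by hydroxy in place of dimethylamino on a saturated chain carbon, three bonds along the chain from an aromatic nitrogen, the same kind of change as that from compound 2 to compound 1, at the same place. For compound 4 a step of a 3.0-fold higher number from compound 3 to compound 4 (0.48 log units; beyond the scatter) is expected, resting on an at least 1.5-fold higher number from compound 2 to compound 1 (0.20 log units; that floor lies within the scatter) and on the value of compound 3 at 2300 nM. The earlier step, from compound 2 to compound 1, is known only as a floor, which leaves the expectation uncertain. Compound 4 is therefore estimated at 7000 nM, with a range from 2500 nM to 30000 nM.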

Compound 4, half-maximal inhibitory concentration: > 30000 nM
Compound 4 ended at the assay's limit (the forecaster's own chance of this, stated with the estimate: 25%); at least 4.2-fold (0.63 log units) between middle value and limit.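

In this assay, hydroxy in place of dimethylamino on a saturated chain carbon, three bonds along the chain from an aromatic nitrogen, gives a clear step on the core with the longer thioether chain: an at least 13-fold higher number from compound 3 to compound 4 (1.11 log units; beyond the scatter). Compound 4 gives > 30000 nM, which is a limit of the assay and not a number, and this limit is shared within the set: the limit of > 30000 nM in this assay, at which 2 of the 4 values shown sit. The change therefore carries to this second core with a step beyond the scatter, but the comparison does not show that its size carries over, or that the two cores respond differently: the same change on two cores in this assay, an at least 1.5-fold higher number (0.20 log units; that floor lies within the scatter) from compound 2 to compound 1 and an at least 13-fold higher number (1.11 log units; beyond the scatter) from compound 3 to compound 4; the limit leaves it open whether they differ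

The compounds shown leave open whether dimethylamino is the specific group that matters on this chain, or whether another amine, such as a pyrrolidine or a primary amine, would hold the lower number seen for compound 3. They also leave open how a carboxylic acid or a methoxy group would read at the same place, and how either end group would behave on a thioether chain of intermediate length.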